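Replacing a Ring with a Chain: What to Expect for Compound 4

The compounds below may be only part of what the source reports. "The series", "measured", "known", "first", "only" and "open" are said of these compounds alone.

Measured in an ADME assay on HCT-116 cells (Homo sapiens) for cytotoxicity, read by CellTiter-Glo, with a stated time of 72 h; on this read-out lower numbers stand for stronger inhibition and higher numbers for weaker inhibition:
- compound 1 `Cc1cc(C)c(S(=O)(=O)N2CCC(N3CCC(C)CC3)CC2)c(C)c1` — > 5000 nM.
- compound 2 `Cc1cc(C)c(S(=O)(=O)N2CCC(N3CCC(Cc4ccccc4F)CC3)CC2)c(C)c1` — > 5000 nM.
- compound 3 `Cc1cc(C)c(S(=O)(=O)N2CCC(N3CCC(CCC#N)CC3)CC2)c(C)c1` — > 5000 nM.

Compound 1 is reported by this assay only as a limit, not a number. The same holds for compound 2. It also holds for compound 3. All three differ only on a saturated chain carbon bound to a saturated ring carbon, and the steps a step that the two limits leave unreadable from compound 1 to compound 2, a step that the two limits leave unreadable from compound 1 to compound 3 and a step that the two limits leave unreadable from compound 2 to compound 3 cannot be read because every value sits at the limit of > 5000 nM in this assay, at which 3 of the 3 values shown sit.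

Compound 4 `CCCC(=O)NC1CCN(S(=O)(=O)c2c(C)cc(C)cc2C)CC1` is not yet measured. Relative to compound 1 it carries (propylcarbonyl)amino in place of 4-methylpiperidin-1-yl on a saturated ring carbon, the change sitting three ring bonds from the ring nitrogen. No measured step touches that ring carbon, so nothing shown speaks directly to this exchange; the only bearing evidence is the limit of > 5000 nM in this assay, at which 3 of the 3 values shown sit, shared by all three measured compounds. On that basis compound 4 is expected to give 8000 nM, with a likely range from 3000 nM to 30000 nM. The step that the limit leaves unreadable from compound 1 to compound 4 is therefore expected to remain unreadable, most likely as another limit.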

Compound 4, half-maximal inhibitory concentration: > 5000 nM
Compound 4 ended at the assay's limit; the forecaster's own chance of this, stated with the estimate: 85%; the middle value does not contradict the limit.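

In this assay compound 4 is reported only as a limit, as is compound 1, so no step between compound 1 and compound 4 can be read: the limit of > 5000 nM in this assay, at which 4 of the 4 values shown sit.

The compounds shown leave open whether (propylcarbonyl)amino or 4-methylpiperidin-1-yl makes any difference to cytotoxicity, since none gives an actual number.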